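The compounds below may be only part of what the source reports. "The series", "measured", "known", "first", "only" and "open" are said of these compounds alone.

Compound 1 `CCN(CC)S(=O)(=O)c1ccc(S(=O)(=O)N2CCC[C@@H](C(=O)N[C@H]3CC[C@H](OC)CC3)C2)cc1` is the weakest of the three measured compounds in a functional assay on MIA PaCa-2 cells (Homo sapiens) for inhibition, read by MTT assay, with a stated time of 7 days (a higher number here means a weaker inhibitor, a lower number a stronger inhibitor), where compound 1 gives 1350 nM. Going by the values given here, compound 2 `O=C([C@@H]1CCCN(S(=O)(=O)c2ccc(S(=O)(=O)N3CC[C@H](O)C3)cc2)C1)N1CCC(F)(F)CC1` gives 590 nM, and compound 3 `O=C([C@@H]1CCCN(S(=O)(=O)c2ccc(S(=O)(=O)C3COC3)cc2)C1)N1CCC(F)(F)CC1` gives 110 nM; the one single-point step among them, a 5.4-fold lower number from compound 2 to compound 3 (0.73 log units; beyond the scatter), sits on a sulfonyl sulfur. Compound 4 `CCN(CC)S(=O)(=O)c1ccc(S(=O)(=O)N2CCC[C@@H](C(=O)N[C@H]3CCOC3)C2)cc1` differs from compound 1 at a different place: oxolan-3-yl in place of 4-methoxycyclohexyl on an amide-type nitrogen. Among the compounds with values here, no measured step touches the amide-type nitrogen, so the step from compound 2 to compound 3 does not bear on this change, and nothing seen here points in either direction. Compound 4 is therefore expected to stay close to compound 1, with an expected step of no change at the digits printed from compound 1 to compound 4 (within the scatter) within the scatter. The estimate for compound 4 in this assay is 1350 nM, with a range from 450 nM to 4000 nM.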

Compound 4, half-maximal inhibitory concentration: 1670 nM
Estimate against measurement, compound 4: 1.2-fold (0.09 log units) below; measured number inside the range.
By their numbers in this assay, from the lowest: compound 3; then compound 2; then compounds 1 and 4 (each within the scatter of the next).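

In this assay, going by these compounds alone, oxolan-3-yl in place of 4-methoxycyclohexyl on the amide-type nitrogen gives a 1.2-fold higher number from compound 1 to compound 4 (0.09 log units; within the scatter), the only measured step at this position. A six-membered ring of carbon only and a five-membered ring with 1 hetero atom therefore cannot be told apart here, although the change also leaves one defined stereocentre fewer in the group. No measurement available here explains this result. From the compounds shown here alone, whether an amine or a carboxylic acid on this nitrogen would read differently remains open, as does how oxetan-3-yl on the sulfonyl sulfur would act on the core of compound 4.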